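Swapping methoxy for formyl on a compound measured for cell growth inhibition

A few compounds are considered here, and "the series" means these few. Any claim that something is new, unique, unknown or untested is made for them only; others in the source may bear on it.

Measured compounds:
- compound 1, `c1ccc(-c2cn3ccnc3c(-c3ccc4ncn(C5CCCCC5)c4c3)n2)cc1`: 5.25%
- compound 2, `COc1ccc(-c2cn3ccnc3c(-c3ccc4ncn(C5CCCCC5)c4c3)n2)cc1`: 31.5%

In a functional assay on NCI-H322M cells (Homo sapiens) for inhibition, read by sulforhodamine B assay, with a stated time of 48 h, tested at 10 uM (on this read-out lower numbers stand for less inhibition and higher numbers for more inhibition at the one concentration tested (going by the name of the read-out)), compound 1 gives 5.25%, while compound 2 gives 31.5%. Within the data shown here, the single step between them, a number 26.3 percentage points higher from compound 1 to compound 2 (beyond the scatter), is the only comparison available, and it places compound 2 at the top of the two numbers, beyond the scatter above compound 1.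

Compound 3, `O=Cc1ccc(-c2cn3ccnc3c(-c3ccc4ncn(C5CCCCC5)c4c3)n2)cc1`, has not yet been measured. It differs from compound 2 in one place: formyl in place of methoxy on an aromatic carbon.

Among the measured compounds shown here, no measured step changes a methoxy into a formyl, so the only guide is the step from compound 1 to compound 2, which showed that a substituent at this position can lift inhibition by a modest amount. Whether formyl behaves like methoxy, like hydrogen, or unlike either cannot be read from two compounds. The estimate for compound 3 is therefore set between the two measured values, with wide bounds: 20%, ranging from 0% to 45%, which corresponds to an expected step of a number 11.5 percentage points lower from compound 2 to compound 3 (beyond the scatter).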

Compound 3, a percentage reported as inhibition, at one concentration (the size of the read-out at that concentration, not a potency): 11.2%
Beside the measured number, compound 3's estimate is 8.8 percentage points above it; measured number inside the range.
By their numbers in this assay, from the lowest: compounds 1 and 3 (each within the scatter of the next); then compound 2.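

In this assay the change to formyl brings a number 20.3 percentage points lower from compound 2 to compound 3 (beyond the scatter) and so shows that the gain seen with methoxy does not carry over to every group placed at this position. Formyl in place of hydrogen brings a number 6 percentage points higher from compound 1 to compound 3 (within the scatter) and so leaves the formyl compound impossible to tell apart from the unsubstituted one on this read-out. Methoxy and formyl match in their counts of heavy atoms and hydrogen-bond acceptors, so these counts alone do not decide the result here, and of the three compounds only compound 2 stands clear of the other two. Nothing measured here offers a reason for the difference between the two groups. The compounds shown leave open whether the gain belongs to methoxy alone or extends to related groups, such as ethoxy, hydroxyl or an amine, on the same aromatic carbon. They also leave open whether a carboxylic acid or a hydroxymethyl group, both close relatives of formyl, would stay level with compound 1 and compound 3.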